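The compounds below may be only part of what the source reports. "The series", "measured", "known", "first", "only" and "open" are said of these compounds alone.

Compound 3 `CCCNc1cccnc1-c1ccc(C(=O)Nc2ccc(C(C)(C)C)cc2)cc1` gives 37 nM in a functional assay for antagonist activity at transient receptor potential cation channel subfamily V member 1 (Rattus norvegicus) (on this read-out higher numbers stand for weaker inhibition and lower numbers for stronger inhibition), the lowest of the two numbers shown. Compound 1 `Cc1cccnc1-c1ccc(C(=O)Nc2ccc(C(C)C)cc2)cc1` gives 43 nM in this assay, within the scatter of compound 3. Compound 2 `Cc1cccnc1-c1ccc(C(=O)Nc2ccc(F)cc2)cc1` reaches only a limit of the assay, > 4000 nM, so it is not a number (the limit of > 4000 nM in this assay, at which 1 of the 3 values shown sits). Within the data shown here, the only measured step, an at least 93-fold higher number from compound 1 to compound 2 (1.96 log units; beyond the scatter), changes the group on the amide-bearing ring, not the position altered here. Compound 4 `CC(C)(C)c1ccc(NC(=O)c2ccc(-c3ncccc3-c3ncc[nH]3)cc2)cc1` differs from compound 3 by 1H-imidazol-2-yl in place of propylamino on an aromatic carbon. Among the measured compounds shown here, no measured step touches this position, so nothing here sets the size of the change. A small step is expected, a 1.6-fold higher number from compound 3 to compound 4 (0.21 log units; within the scatter), and compound 4 is estimated at 60 nM, between 15 nM and 250 nM.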

Compound 4, half-maximal inhibitory concentration: 694 nM
Beside the measured number, compound 4's estimate is 12-fold (1.06 log units) below it; the measured number lies above the stated range.
By their numbers in this assay, from the lowest: compounds 3 and 1 (each within the scatter of the next); then compound 4. At a limit, above all of these: compound 2.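

In this assay, 1H-imidazol-2-yl in place of propylamino brings a 19-fold higher number from compound 3 to compound 4 (1.27 log units; beyond the scatter), so this position does respond to the group it carries. Counts alone do not settle the outcome, since both groups have the same hydrogen-bond donor and acceptor counts and no net charge. Nothing measured here explains the size of this step. Still open, as far as these compounds go, is whether any ring at this position gives such a step, or only this one. A plain amine or a longer chain such as butylamino would show how much the propyl chain itself matters.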